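The source may hold more compounds than are shown below. What is called first, only, known or untested is meant among the compounds shown, and "the series" means these compounds.

Three compounds share one core and differ only in the aromatic group carried on a carbon that is double-bonded to nitrogen. Compound 1 `CN(C)CCn1cnnc1-c1cc(Oc2ccc(NC(=O)N/N=C/c3ccccc3)cc2F)ccn1` carries a plain phenyl there, and in a functional assay on NCI-H460 cells (Homo sapiens) for cytotoxicity, read by MTT assay, with a stated time of 72 h (a lower number here means a stronger inhibitor, a higher number a weaker inhibitor), compound 1 gives 1780 nM. Compound 2 `CN(C)CCn1cnnc1-c1cc(Oc2ccc(NC(=O)N/N=C/c3ccc(F)cc3F)cc2F)ccn1` carries a 2,4-difluorophenyl, and in this assay compound 2 gives 1930 nM. Compound 3 `CN(C)CCn1cnnc1-c1cc(Oc2ccc(NC(=O)N/N=C/c3ccc(O)c(O)c3)cc2F)ccn1` carries a 3,4-dihydroxyphenyl, and in this assay compound 3 gives 1930 nM. The steps between them are small: a 1.1-fold higher number from compound 1 to compound 2 (0.04 log units; within the scatter), a 1.1-fold higher number from compound 1 to compound 3 (0.04 log units; within the scatter) and no change at the digits printed from compound 2 to compound 3 (within the scatter). On these numbers compound 3 stands level with compound 2, the two together sitting at the highest of the three values, while compound 1, its furthest neighbour, is still within the scatter of it.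

Compound 4 `CN(C)CCn1cnnc1-c1cc(Oc2ccc(NC(=O)N/N=C/c3cc(Br)c(O)c(Br)c3)cc2F)ccn1` has not been measured. It differs from compound 3 in one place: 3,5-dibromo-4-hydroxyphenyl in place of 3,4-dihydroxyphenyl on a carbon with a double bond to nitrogen. The three steps seen so far all swap the group at this same carbon, and all stay within the scatter, so no change beyond the scatter is expected in this assay this time either. The step expected from compound 3 to compound 4 is a 1.0-fold lower number from compound 3 to compound 4 (0.01 log units; within the scatter). Compound 4 is therefore expected to give about 1900 nM in this assay, within a range from 900 nM to 4000 nM.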

Compound 4, half-maximal inhibitory concentration: 3760 nM
Estimate against measurement, compound 4: 2.0-fold (0.30 log units) below; low and high end bracket the measured number.
By their numbers in this assay, from the lowest: compounds 1, 2, 3 and 4 (each within the scatter of the next, the first and the last beyond it).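

Within the data shown here, the 3,5-dibromo-4-hydroxyphenyl group gives the first step at this carbon to pass beyond the scatter, though only modestly: there is a 2.1-fold higher number from compound 1 to compound 4 (0.32 log units; beyond the scatter) in this assay. The same group cannot be told apart from the other two substituted rings, with a 1.9-fold higher number from compound 3 to compound 4 (0.29 log units; within the scatter) and a 1.9-fold higher number from compound 2 to compound 4 (0.29 log units; within the scatter), so only the comparison with the plain phenyl of compound 1 separates it, and compound 2 and compound 3 do not separate from compound 1 in the same way. Nothing measured here explains why two bromine atoms and one oxygen in place of two oxygens give these numbers.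

The compounds shown do not tell whether the bromine atoms or the remaining hydroxyl group matter more for the step from compound 1, since a phenyl carrying only one bromine, or only one hydroxyl, does not appear among them. On these data alone, it also remains open how this assay would respond to an amine or a carboxylic acid on the phenyl, or to a longer chain in place of the ring at this carbon.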